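A few compounds are considered here, and "the series" means these few. Any claim that something is new, unique, unknown or untested is made for them only; others in the source may bear on it.

Measured so far in a physicochemical assay for lipophilicity, at pH 7.4; a higher number here means a more lipophilic compound, a lower number a more polar compound:
compound 1 (`COc1cc2c(cc1OC)[C@H](C)C(=O)N(C)C=C2`): 3.4
compound 2 (`CCc1ccc2c(c1)C=CN(C)C(=O)[C@@H]2C`): 5.9
compound 3 (`CC1C(=O)N(C)C=Cc2cc(OCC(C)(C)O)ccc21`): 3.6

Compound 2 stands highest of the three. Compound 3 and compound 1 both lie lower by more than the scatter, and those two lie within the scatter of each other. Among the compounds with values here, no two measured compounds differ in one place only, so no measured step is available to size the next change directly.

The next compound is compound 4 (`C[C@H]1C(=O)N(C)C=Cc2cc(CC3CCOCC3)ccc21`), still to be measured in this assay. Its difference from compound 2 is oxan-4-yl in place of methyl on a saturated chain carbon bound to an aromatic carbon. Cut one bond further out, the same difference reads ethyl to (oxan-4-yl)methyl.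

Within the data shown here, a downward step beyond the scatter is expected, though this is a judgement from only three compounds. Compound 2 at 5.9 sits at the top of the series, while compound 3 gives 3.6 and compound 1 gives 3.4. Compound 4 is expected to fall between these levels, not to reach the lower pair. The estimated step runs a number 1.30 log units lower from compound 2 to compound 4 (beyond the scatter). Among the measured compounds shown here, with no matched pair behind it, the range is kept wide. For compound 4 the expected value is 4.6, with an estimated range of 3.8 to 5.4.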

Compound 4, distribution coefficient: 5.4
Compound 4: middle estimate off by 0.80 log units, on the low side, and the stated range covers the measured number.
By their numbers in this assay, from the lowest: compounds 1 and 3 (each within the scatter of the next); then compound 4; then compound 2.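

In this assay, the first one-place change available in the series, oxan-4-yl in place of methyl on a saturated chain carbon bound to an aromatic carbon, gives a number 0.50 log units lower from compound 2 to compound 4 (beyond the scatter). This puts a first measured size on a change at this position: the entering group has 6 heavy atoms, one six-membered non-aromatic ring and 1 hydrogen-bond acceptor, while the leaving methyl has 1 heavy atom, and the step is modest though beyond the scatter. No measurement shown explains why the step has this size.

The compounds shown leave open how the step divides between the ring and its oxygen: cyclohexyl at the same place would separate the two, and piperidin-4-yl would show the effect on the number of nitrogen as the ring hetero atom. Also open, on these data alone, is whether the same change gives a similar step in this assay from another starting compound, as this single pair offers no second reading.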